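Working notes: chloro to hydrogen on a weakly cytotoxic pair

A few compounds are considered here, and "the series" means these few. Any claim that something is new, unique, unknown or untested is made for them only; others in the source may bear on it.

Measured so far:
compound 1 `Cc1nnc(SCc2cc(=O)c3ccccc3o2)s1` — > 25000 nM
compound 2 `Cc1nnc(SCc2cc(=O)c3cc(Cl)ccc3o2)o1` — > 25000 nM

In a functional assay on HeLa cells (Homo sapiens) for cytotoxicity, read by MTT assay, with a stated time of 72 h (on this read-out higher numbers stand for weaker inhibition and lower numbers for stronger inhibition), compound 1 returns only a limit of the assay, > 25000 nM. Compound 2 likewise returns only a limit in this assay, > 25000 nM. Both readings sit at the same ceiling, (the limit of > 25000 nM in this assay, at which 2 of the 2 values shown sit), so neither compound shows measurable inhibition of HeLa growth and nothing separates the two. Among the measured compounds shown here, compound 2 therefore stands at the top of what the assay can report; a limit is all that is known of it, and the one further value is a limit as well.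

Compound 3 `Cc1nnc(SCc2cc(=O)c3ccccc3o2)o1` is not yet measured in this assay. Relative to compound 2 the change is hydrogen in place of chloro on an aromatic carbon. For the measured compounds named here, no step between measured compounds exists to calibrate this change. Since compound 2 gives only the limit > 25000 nM, the step from compound 2 to compound 3 is expected to be none beyond the scatter, a step that the limit leaves unreadable from compound 2 to compound 3, and compound 3 is expected to return a limit again. The estimate for compound 3 is 40000 nM, within 15000 nM to 120000 nM.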

Compound 3, half-maximal inhibitory concentration: > 25000 nM
Compound 3: only a limit was reported (the forecaster's own chance of this, stated with the estimate: 85%); the middle value is on the limit's open side.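

In this assay compound 3 gives > 25000 nM, which is a limit. No step can be read from compound 2 to compound 3 or from compound 1 to compound 3: the limit of > 25000 nM in this assay, at which 3 of the 3 values shown sit.

The compounds shown leave open whether hydrogen in place of chloro, or 5-methyl-1,3,4-oxadiazol-2-yl in place of 5-methyl-1,3,4-thiadiazol-2-yl, changes the read-out at all.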